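The source may hold more compounds than are shown below. What is called first, only, known or untested is meant among the compounds shown, and "the series" means these compounds.

Compound 1 `CC(C)N(Cc1cccc(OCCCCCC(=O)O)c1)C(=O)c1ccc(-c2cccc3ccccc23)cc1`: in an ADME assay on HEK293 cells (Homo sapiens) for cytotoxicity, read by CellTiter-Glo and resazurin assay, with a stated time of 72 h (on this read-out higher numbers stand for an effect only at larger amounts of compound and lower numbers for an effect already at smaller amounts), compound 1 gives > 26000 nM, which is a limit of the assay and not a number.
Compound 2 `COc1cccc(-c2ccc(C(=O)N(Cc3cccc(OCCCCCC(=O)O)c3)C(C)C)cc2)c1`: in this assay compound 2 gives > 20900 nM, again a limit.
Compound 3 `COc1cc(OC)cc(-c2ccc(C(=O)N(Cc3cccc(OCCCCCC(=O)O)c3)C(C)C)cc2)c1`: in this assay compound 3 gives > 26000 nM, also a limit.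

Compound 3 therefore stands at a limit, and none of the three measured compounds gives a number in this assay. All three sit at either the limit of > 20900 nM in this assay, at which 1 of the 3 values shown sits, or (the limit of > 26000 nM in this assay, at which 2 of the 3 values shown sit), so the steps among them, namely a step that the two limits leave unreadable from compound 1 to compound 2, a step that the two limits leave unreadable from compound 1 to compound 3 and a step that the two limits leave unreadable from compound 2 to compound 3, cannot be sized. Compound 4 `CC(C)N(Cc1cccc(OCCCCCC(=O)O)c1)C(=O)c1ccc(-c2c[nH]c3ccccc23)cc1` differs from compound 3 by 1H-indol-3-yl in place of 3,5-dimethoxyphenyl on an aromatic carbon. Going by the values given here, no measured step has a readable size that bears on this change, so the only guide is that each of the three measured compounds reaches the limit in this assay. On that basis compound 4 is expected to behave alike, with an expected step that the limit leaves unreadable from compound 3 to compound 4, nothing beyond the scatter. Compound 4 is estimated at 30000 nM, between 10000 nM and 100000 nM, most likely again reported only as a limit.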

Compound 4, half-maximal effective concentration: > 26000 nM
Compound 4 ended at the assay's limit (the forecaster's own chance of this, stated with the estimate: 85%); the middle value lies beyond the limit too.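

Compound 4 also gives only a limit, like compound 1, compound 2 and compound 3, so no step among these four can be read in this assay. The compounds shown leave open whether any group at this place would give a measurable effect on these cells.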